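This account rests on a few compounds, and the source may have more. Where it says the series, first, only, none or still open, it means among the compounds named here.

Measured so far:
- compound 1 `c1ccc(-c2nc(SCC3CCCCO3)[nH]c2-c2ccccc2)cc1`: 210 nM
- compound 2 `CCOC(CCSc1nc(-c2ccccc2)c(-c2ccccc2)[nH]1)OCC`: 69 nM

Both compounds share a core that carries a sulfur-linked side chain, and both were tested in an assay on microsomes from liver for inhibition of sterol O-acyltransferase 1 (Rattus norvegicus); on this read-out higher numbers stand for weaker inhibition and lower numbers for stronger inhibition. On that read-out compound 2 has the lowest of the two numbers; the nearest is compound 1, whose number is higher, and the step of a 3.0-fold lower number from compound 1 to compound 2 (0.48 log units; beyond the scatter) lies beyond the scatter. Compound 3 `c1ccc(CSc2nc(-c3ccccc3)c(-c3ccccc3)[nH]2)cc1` has not yet been measured. It differs from compound 2 in one place: phenyl in place of 2,2-diethoxyethyl on a saturated chain carbon bound to a sulfur. In other words, the 2,2-diethoxyethyl chain is replaced by phenyl on the saturated chain carbon bound to the sulfur, which turns the 3,3-diethoxypropyl arm into a benzyl arm.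

For the measured compounds named here, only one measured step bears on this change, a 3.0-fold lower number from compound 1 to compound 2 (0.48 log units; beyond the scatter), and it concerns a different exchange at the same place, so it sets only a rough scale. For this reason no step beyond the scatter is firmly expected in either direction for compound 3 in this assay. Compound 3 is estimated at 100 nM with a range of 30 nM to 400 nM, which means an expected step of a 1.4-fold higher number from compound 2 to compound 3 (0.16 log units; within the scatter).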

Compound 3, half-maximal inhibitory concentration: 290 nM
Estimate against measurement, compound 3: 2.9-fold (0.46 log units) below, within the range that was stated.
By their numbers in this assay, from the lowest: compound 2; then compounds 1 and 3 (each within the scatter of the next).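

Exchanging 2,2-diethoxyethyl for phenyl on a saturated chain carbon bound to a sulfur weakens inhibition in this assay with a 4.2-fold higher number from compound 2 to compound 3 (0.62 log units; beyond the scatter) beyond the scatter, so this place on the side chain does respond to the choice of group. The two compounds whose groups at this place contain a ring show no such separation, with a 1.4-fold higher number from compound 1 to compound 3 (0.14 log units; within the scatter) lying within the scatter, which means that oxan-2-yl and phenyl cannot be told apart here. Among these three compounds, then, only the open-chain 2,2-diethoxyethyl group of compound 2 stands apart, but no measurement shown here explains why it gives the stronger inhibition.

The compounds shown leave open whether the advantage of compound 2 comes from the two oxygen atoms of its 2,2-diethoxyethyl group or simply from having an open chain at this place. A plain hexyl chain, holding no oxygen, would separate those two readings, while an amine or a carboxylic acid at the end of the chain would test quite different end groups on the same arm.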